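The compounds below may be only part of what the source reports. "The series", "measured", "known", "first", "only" and "open" are said of these compounds alone.

Measured compounds:

Compound 1, `Cc1cc(C)nc(NS(=O)(=O)c2ccc(NCc3coc4ccccc4c3=O)cc2)n1`, gives 55800 nM in a functional assay on A549 cells (Homo sapiens) for cytotoxicity, read by sulforhodamine B assay, with a stated time of 72 h; on this read-out higher numbers stand for weaker inhibition and lower numbers for stronger inhibition.
Compound 2, `O=c1c(CNc2ccc(S(=O)(=O)Nc3ncccn3)cc2)coc2ccccc12`, gives 85300 nM in this assay.
Compound 3, `Cc1cc(C)nc(NS(=O)(=O)c2ccc(N3C(=O)/C(=C/c4coc5ccccc5c4=O)N=C3c3ccccc3)cc2)n1`, gives 63200 nM in this assay.

All three measured compounds carry a sulfonamide attached to a pyrimidine, and in each case the read-out lies in a range where the values of the three compounds sit within the usual scatter of one another. Compound 1 and compound 2 share one core, while compound 3 has a different core; the difference between the two cores is not broken down here.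

The change from compound 1 to compound 2 is pyrimidin-2-yl in place of 4,6-dimethylpyrimidin-2-yl on a sulfonamide nitrogen. This change produced a 1.5-fold higher number from compound 1 to compound 2 (0.18 log units; within the scatter).

Compound 4, `O=C1/C(=C/c2coc3ccccc3c2=O)N=C(c2ccccc2)N1c1ccc(S(=O)(=O)Nc2ncccn2)cc1`, has not yet been measured in this assay. It stands to compound 3 as compound 2 stands to compound 1: the change is pyrimidin-2-yl in place of 4,6-dimethylpyrimidin-2-yl on a sulfonamide nitrogen, made at the same place, a sulfonamide nitrogen whose other neighbour is the sulfonyl sulfur. As the change is the same one already seen, the expectation rests on that earlier step: since the step from compound 1 to compound 2 stayed within the scatter, the step from compound 3 to compound 4 is expected to be of a similar small size, a 1.3-fold higher number from compound 3 to compound 4 (0.13 log units; within the scatter), with the number drifting somewhat higher but not clearly outside the scatter of compound 3. Compound 4 is therefore estimated at 85000 nM, with a plausible range from 42000 nM to 170000 nM.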

Compound 4, half-maximal inhibitory concentration: 40500 nM
For compound 4 the middle estimate is 2.1-fold (0.32 log units) above the measured one; the whole stated range lies above it.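

In this assay, pyrimidin-2-yl in place of 4,6-dimethylpyrimidin-2-yl on a sulfonamide nitrogen now gives a 1.6-fold lower number from compound 3 to compound 4 (0.19 log units; within the scatter) on the core of compound 3. Set beside the step on the core of compound 1, the result on the second core does not differ from the first by more than two such steps would be expected to scatter: the same change on two cores in this assay, a 1.5-fold higher number (0.18 log units; within the scatter) from compound 1 to compound 2 and a 1.6-fold lower number (0.19 log units; within the scatter) from compound 3 to compound 4, 2.4-fold (0.38 log units) apart, within the scatter of two such steps This shows that on both of these cores the change stayed within the scatter, so the small size of the step carried from one core to the other; it does not establish any direction for the change, and it says nothing about how the change would behave on a further core or in another assay.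

The compounds shown leave open whether a different group on the sulfonamide nitrogen, such as a thiazole ring or an acetyl group, would give a step beyond the scatter. Also open, going by these compounds, is whether a pyrimidine ring with a single methyl group, or a methoxy group in place of the methyl groups, would read any differently from the two pyrimidine groups compared here.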